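The source may report more compounds than this note shows. Statements on the series, on what has been measured and on what is new or still open speak of the compounds shown alone.

Measured so far in a functional assay on LNCaP cells (Homo sapiens) for antiproliferative activity, read by MTT assay, with a stated time of 72 h, in the presence of a further agent that is not named here; on this read-out lower numbers stand for stronger inhibition and higher numbers for weaker inhibition:
Compound 1 `CC1(CN2C(=O)S/C(=C\c3ccc(O)c(C(F)(F)F)c3)C2=O)CCCCC1` gives 6000 nM
Compound 2 `O=C1S/C(=C\c2ccc(O)c(C(F)(F)F)c2)C(=O)N1CC(CC(F)(F)F)CC(F)(F)F` gives 2200 nM

Compound 2 holds the lower of the two numbers at 2200 nM and compound 1 lies higher at 6000 nM with a gap beyond the scatter. Compound 3 `CC(CN1C(=O)S/C(=C\c2ccc(O)c(C(F)(F)F)c2)C1=O)(CC(F)(F)F)CC(F)(F)F` has not yet been measured. Its difference from compound 2 is methyl in place of hydrogen on a saturated chain carbon bound to three saturated chain carbons and amounts to methyl in place of hydrogen on a saturated chain carbon bound to three saturated chain carbons. Within the data shown here, no measured pair shows this change alone, and compound 1 and compound 2 differ in more than one place, so their gap cannot size it. The expected step is a 1.1-fold lower number from compound 2 to compound 3 (0.04 log units; within the scatter) and no change beyond the scatter is expected in this assay with neither direction favoured. The estimate for compound 3 is 2000 nM with 700 nM to 6000 nM as its expected range.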

Compound 3, half-maximal inhibitory concentration: 1500 nM
Compound 3: middle estimate off by 1.3-fold (0.12 log units), on the high side, and the stated range covers the measured number.
By their numbers in this assay, from the lowest: compounds 3 and 2 (each within the scatter of the next); then compound 1.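

In this assay, among these compounds, the change from hydrogen to methyl on a saturated chain carbon bound to three saturated chain carbons can be read on its own for the first time, and it gives a 1.5-fold lower number from compound 2 to compound 3 (0.17 log units; within the scatter) and so no shift beyond the scatter. This position therefore takes the added methyl without a measurable change in antiproliferative activity, at least on the side chain that compound 2 and compound 3 share. No measured property is available to explain this result.

From the compounds shown here alone, it remains open whether an ethyl group, a hydroxyl group or an amine at this carbon would leave the number within the scatter as well. Going by these compounds, it is also open whether methyl in place of hydrogen would behave in the same way on the different side chain of compound 1.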